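Removal of the aniline-ring fluoro: compound 2 to compound 4

The source may report more compounds than this note shows. Statements on the series, on what has been measured and on what is new or still open speak of the compounds shown alone.

Of the compounds shown here, three of the shared core have been measured in a functional assay on T47D cells (Homo sapiens) for inhibition, read by CCK-8 assay, with a stated time of 72 h, tested at 1 uM; on this read-out lower numbers stand for less inhibition of growth and higher numbers for more inhibition of growth at the one concentration tested. Compound 1 `CN(C)C(=O)c1cc2cnc(Nc3ccc(NC(=O)C4(C(=O)Nc5cccc(O)c5)CC4)cc3)nc2n1C1CCCC1` gives 80.7%, compound 3 `Cc1cccc(NC(=O)C2(C(=O)Nc3ccc(Nc4ncc5cc(C(=O)N(C)C)n(C6CCCC6)c5n4)cc3)CC2)c1` gives 45.7%, and the step of a number 35 percentage points lower from compound 1 to compound 3 (beyond the scatter). Compound 2 `CN(C)C(=O)c1cc2cnc(Nc3ccc(NC(=O)C4(C(=O)Nc5ccc(F)cc5)CC4)cc3F)nc2n1C1CCCC1` gives 6.3%, the lowest of the three; compound 3 lies nearest, compound 1 furthest, both gaps beyond the scatter.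

Within the data shown here, compound 4 `CN(C)C(=O)c1cc2cnc(Nc3ccc(NC(=O)C4(C(=O)Nc5ccc(F)cc5)CC4)cc3)nc2n1C1CCCC1` differs from compound 2 by hydrogen in place of fluoro on an aromatic carbon, so of the two fluoro groups in compound 2 only the one on the amide-side ring remains in compound 4. Among the measured compounds shown here, no measured step concerns this change: the one step recorded, from compound 1 to compound 3, alters the amide-side ring, and compounds 1 and 3 also differ from compound 2 at that ring, so their higher numbers cannot be assigned to the missing fluoro alone. The expected step of a number 21.7 percentage points higher from compound 2 to compound 4 (beyond the scatter) is therefore modest and uncertain, leaning upward. Compound 4 is estimated at 28%, with a range from 5% to 60%.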

Compound 4, percent growth inhibition at one concentration: 74.7%
Compound 4: middle estimate off by 46.7 percentage points, on the low side, outside the stated range (above it).
By their numbers in this assay, from the lowest: compound 2; then compound 3; then compounds 4 and 1 (each within the scatter of the next).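

Among these compounds, with the 4-fluorophenyl on the amide-type nitrogen held fixed, hydrogen in place of fluoro gives a number 68.4 percentage points higher from compound 2 to compound 4 (beyond the scatter) and so shows that this one aromatic carbon, ortho to a large group and meta to a large group, matters strongly in this pair, which the earlier compounds could not separate from changes at the amide-side ring. With hydrogen at this position, the amide-side ring can be read on its own: 4-fluorophenyl in place of 3-methylphenyl gives a number 29 percentage points higher from compound 3 to compound 4 (beyond the scatter) in this comparison. 4-Fluorophenyl in place of 3-hydroxyphenyl gives a number 6 percentage points lower from compound 1 to compound 4 (within the scatter) so these two amide-side groups are not told apart here.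

On these data alone, whether chloro, methoxy or an amine at this position would stay close to compound 4 or fall towards compound 2 remains open. Also open, as far as these compounds go, is whether fluoro there would lower the number with 3-hydroxyphenyl on the amide side, and no evidence at hand explains the step from fluoro to hydrogen.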